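Removing a Methoxy from Compound 1: Expected Liver Microsome Stability

This account rests on a few compounds, and the source may have more. Where it says the series, first, only, none or still open, it means among the compounds named here.

Measured so far:
- Compound 1, `COC(=O)Nc1cc(-c2cnc(OC[C@@](C)(N)CC(C)C)c(OC)c2)ccn1`: 79%
- Compound 2, `CC(=O)Nc1cc(-c2cc(F)c(OC[C@@H](N)CC(C)C)cc2F)ccn1`: 90%

Two compounds have been run in an ADME assay on microsomes from liver (Rattus norvegicus) for metabolic stability, read by LC-MS, using NADPH, with a stated time of 10 min, tested at 0.5 uM; on this read-out higher numbers stand for a more stable compound and lower numbers for a less stable compound. Compound 1 gives 79%, and compound 2 gives 90%. Of these two numbers, compound 1 stands lowest, and compound 2 is the nearest, with a number higher by a gap that is beyond the usual scatter.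

Compound 3, `COC(=O)Nc1cc(-c2ccc(OC[C@@](C)(N)CC(C)C)nc2)ccn1`, has not yet been measured. Compared with compound 1, the change is hydrogen in place of methoxy on an aromatic carbon. The step from compound 1 to compound 3 is shown only in structure; no measured pair in this set carries the same change, so its size is unknown. A step of small size is expected, tending upward if anything, but quite possibly none beyond the scatter. Compound 3 is therefore estimated at 82%, within a range of 62% to 95%, which corresponds to an expected step of a number 3 percentage points higher from compound 1 to compound 3 (within the scatter).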

Compound 3, percent of the compound remaining: 96%
The estimate for compound 3 lay 14 percentage points below the measured number; measured number outside the range, above it.
By their numbers in this assay, from the lowest: compound 1; then compounds 2 and 3 (each within the scatter of the next).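

In this assay, hydrogen in place of methoxy on this aromatic carbon gives a number 17 percentage points higher from compound 1 to compound 3 (beyond the scatter). This is the only pair shown that differs in one place, and it shows that the group on this carbon, ortho to a (2-amino-2,4-dimethylpentyl)oxy group and two atoms from the ring nitrogen, matters for this read-out, with the methoxy compound being the less stable of the two. Nothing measured here accounts for the size or direction of this step.

On these data alone, only methoxy and hydrogen can be compared at this carbon, so it remains open how an ethoxy group, a hydroxyl or an amine there would behave. Among the compounds shown here, compound 2 differs from compound 1 and compound 3 in more than one place, so no step involving it can be read.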